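A few compounds are considered here, and "the series" means these few. Any claim that something is new, unique, unknown or untested is made for them only; others in the source may bear on it.

Compound 1 `NC(=O)/C=C1\CCc2c(F)cccc21` gives 34% in a functional assay on the whole organism with Rattus norvegicus as the target, at a dose of 20 mg/kg by the oral route; a lower number here means less inhibition, a higher number more inhibition at the dose given (going by the name of the read-out); compound 2 `O=C(/C=C1\CCc2cc(F)c(F)cc21)NC1CC1` gives 48%; compound 3 `O=C(/C=C1\CCc2ccc(F)cc21)NC1CC1` gives 7%.

Between compound 3 and compound 2 the change is fluoro in place of hydrogen on an aromatic carbon, and it brought a number 41 percentage points higher from compound 3 to compound 2 (beyond the scatter). The difference between the core of compound 1 and the core of compound 3 is not broken down here. Compound 4 `NC(=O)/C=C1\CCc2c(F)ccc(F)c21` is still to be measured; it differs from compound 1 by fluoro in place of hydrogen on an aromatic carbon. Among the compounds with values here, this is the same kind of change as the one between compound 3 and compound 2, yet not the same: there the entering fluoro was ortho to a fluoro group, meta to a fused ring and para to a fused ring, while here it is ortho to a fused ring, meta to a fused ring and para to a fluoro group. Within the data shown here, for compound 4 a rise is expected, a number 21 percentage points higher from compound 1 to compound 4 (beyond the scatter), smaller than the earlier step, resting on a number 41 percentage points higher from compound 3 to compound 2 (beyond the scatter) as the only precedent. Compound 4 is estimated at 55%, between 30% and 80%.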

Compound 4, a percentage reported as inhibition, in the whole organism at one dose (the size of the read-out at that dose, not a potency): 67%
Compound 4: middle estimate off by 12 percentage points, on the low side; the range from low to high includes it.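

In this assay, fluoro in place of hydrogen on an aromatic carbon gave a number 33 percentage points higher from compound 1 to compound 4 (beyond the scatter), and the change carried over from one core to the other with a gain of similar size: the same change on two cores in this assay, a number 41 percentage points higher (beyond the scatter) from compound 3 to compound 2 and a number 33 percentage points higher (beyond the scatter) from compound 1 to compound 4, 8 percentage points apart, within the scatter of two such steps These two pairs do not show that the gain would hold on further cores, and the entering fluoro stands in a different place in each pair. The read-out also gives the size of the inhibition at one oral dose, not a potency.

The compounds shown leave open whether chlorine, a methoxy group or a trifluoromethyl group in the same place would give a similar step. They also leave open how an amide carrying a longer chain would behave on either core.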